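The source may hold more compounds than are shown below. What is called first, only, known or untested is meant among the compounds shown, and "the series" means these compounds.

Working notes on a small set of fused bicyclic lactams tested in a functional assay on MCF7 cells (Homo sapiens) for antiproliferative activity, read by MTT assay, with a stated time of 72 h; a lower number here means a stronger inhibitor, a higher number a weaker inhibitor. Compound 1 `COc1ncc(-c2ccc3c(c2)NC(=O)CO3)cc1NS(=O)(=O)c1ccc(F)cc1` gives 32300 nM in this assay. For compound 2 `COc1ncc(-c2ccc3c(c2)N(c2ccc(F)cc2)C(=O)CO3)cc1NS(=O)(=O)c1ccc(F)cc1` the same assay returns only a limit, > 40000 nM. For compound 3 `O=C1COc2ccc(-c3cnc4ccccc4c3)cc2N1c1ccc(F)cc1` it again returns only a limit, > 40000 nM. The change hydrogen in place of 4-fluorophenyl on an amide-type nitrogen in a ring yields an at least 1.2-fold lower number from compound 2 to compound 1 (0.09 log units; that floor lies within the scatter), a floor set because of the limit of > 40000 nM in this assay, at which 2 of the 3 values shown sit. How the core of compound 2 differs from the core of compound 3 is not broken down here. Compound 4 `O=C1COc2ccc(-c3cnc4ccccc4c3)cc2N1` awaits measurement; it carries the same change, (hydrogen in place of 4-fluorophenyl on an amide-type nitrogen in a ring), at a place described in the same words. The step expected is a step that the limit leaves unreadable from compound 3 to compound 4, resting on an at least 1.2-fold lower number from compound 2 to compound 1 (0.09 log units; that floor lies within the scatter) and on the fact that compound 3 shows only its limit. In this assay compound 4 is expected near 45000 nM, estimated between 20000 nM and 100000 nM, quite possibly again reported only as a limit.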

Compound 4, half-maximal inhibitory concentration: > 40000 nM
Compound 4 ended at the assay's limit; the forecaster's own chance of this, stated with the estimate: 60%; the middle value lies beyond the limit too.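

No step can be read between compound 3 and compound 4: in this assay both stand only as limits. As far as these compounds go, whether hydrogen in place of 4-fluorophenyl shifts activity on the core of compound 3 stays open.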